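The source may report more compounds than this note shows. Statements on the series, on what has been measured and on what is new or still open speak of the compounds shown alone.

Measured so far in a functional assay on K562 cells (Homo sapiens) for inhibition, read by sulforhodamine B assay, with a stated time of 48 h, tested at 10 uM; a lower number here means less inhibition, a higher number more inhibition at the concentration tested (going by the name of the read-out):
- compound 1, `COc1ccc(-c2cn3ccnc3c(-c3ccc4ncn(C5CCCCC5)c4c3)n2)cc1`: 92%
- compound 2, `Fc1ccc(-c2cn3ccnc3c(-c3ccc4ncn(C5CCCCC5)c4c3)n2)cc1`: 24.7%
- compound 3, `COc1ccccc1-c1cn2ccnc2c(-c2ccc3ncn(C4CCCCC4)c3c2)n1`: 22.6%

Compound 3 gives the lowest of the three numbers. The step of a number 2.1 percentage points lower from compound 2 to compound 3 (within the scatter) lies within the scatter, so compound 2 and compound 3 cannot be told apart; against compound 1 the step of a number 69.4 percentage points lower from compound 1 to compound 3 (beyond the scatter) is large.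

Compound 4, `Fc1ccccc1-c1cn2ccnc2c(-c2ccc3ncn(C4CCCCC4)c3c2)n1`, is not yet measured. It differs from compound 3 by fluoro in place of methoxy on an aromatic carbon.

Among the measured compounds shown here, the one measured step of the same kind is a number 67.3 percentage points lower from compound 1 to compound 2 (beyond the scatter), a large fall, but it started from a high number. Compound 3 already stands low, so little room remains downward, and no step shown points upward. The expected step of a number 4.6 percentage points lower from compound 3 to compound 4 (within the scatter) is therefore small or none beyond the scatter. For compound 4 in this assay the estimate is 18%, between 5% and 40%.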

Compound 4, a percentage reported as inhibition, at one concentration (the size of the read-out at that concentration, not a potency): 22.8%
Compound 4: the middle estimate sits 4.8 percentage points below what was measured, and the stated range covers the measured number.
By their numbers in this assay, from the lowest: compounds 3, 4 and 2 (each within the scatter of the next); then compound 1.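

In this assay, fluoro in place of methoxy does not give one size of step on the two cores: the same change on two cores in this assay, a number 67.3 percentage points lower (beyond the scatter) from compound 1 to compound 2 and a number 0.2 percentage points higher (within the scatter) from compound 3 to compound 4, 67.5 percentage points apart, beyond the scatter of two such steps. Ortho to a large group, the two groups cannot be told apart, with a number 0.2 percentage points higher from compound 3 to compound 4 (within the scatter), and 2-fluorophenyl and 4-fluorophenyl cannot be told apart either, with a number 1.9 percentage points lower from compound 2 to compound 4 (within the scatter). Only 4-methoxyphenyl stands apart from the other three aryl groups, with a number 69.2 percentage points lower from compound 1 to compound 4 (beyond the scatter).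

On these data alone, whether the high number of compound 1 requires methoxy itself remains open. An ethoxy, hydroxy or amino group in that place would test this.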